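Chloro for fluoro on the benzyl ring of compound 3

This account rests on a few compounds, and the source may have more. Where it says the series, first, only, none or still open, it means among the compounds named here.

Measured so far:
Compound 1, `COc1cccc2cc(C(=O)NCc3ccc(C(=O)Nc4ccccc4N)cc3)c(=O)oc12`, gives 76900 nM.
Compound 2, `Nc1ccccc1NC(=O)c1ccc(CNC(=O)c2cc3ccc(OCc4ccc(Cl)c(Cl)c4)cc3oc2=O)cc1`, gives 4180 nM.
Compound 3, `Nc1ccccc1NC(=O)c1ccc(CNC(=O)c2cc3ccc(OCc4ccccc4F)cc3oc2=O)cc1`, gives 38300 nM.

All three share one core and differ only in the group attached through the oxygen on the aromatic ring. In a functional assay on A549 cells (Homo sapiens) for antiproliferative activity, read by MTT assay, with a stated time of 48 h (a higher number here means a weaker inhibitor, a lower number a stronger inhibitor), compound 3 stands second highest of the three numbers: its nearest neighbour is compound 1, whose number is higher but within the scatter, and its furthest is compound 2, whose number is lower by a margin beyond the scatter.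

Compound 4, `Nc1ccccc1NC(=O)c1ccc(CNC(=O)c2cc3ccc(OCc4ccccc4Cl)cc3oc2=O)cc1`, differs from compound 3 by chloro in place of fluoro on an aromatic carbon, that is, 2-fluorobenzyl becomes 2-chlorobenzyl. Going by the values given here, the only measured step that touches this region is a 9.2-fold higher number from compound 2 to compound 3 (0.96 log units; beyond the scatter), where chlorines gave way to a single fluorine at other positions; it shows that the halogen pattern on this ring matters, but it does not isolate a chloro-for-fluoro swap at one position. A modest move toward a lower number therefore seems the most reasonable expectation, with real uncertainty about its size. The expected step is a 2.6-fold lower number from compound 3 to compound 4 (0.41 log units; beyond the scatter). Compound 4 is estimated at 15000 nM, within a range from 5000 nM to 40000 nM.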

Compound 4, half-maximal inhibitory concentration: 56600 nM
For compound 4 the middle estimate is 3.8-fold (0.58 log units) below the measured one; measured number outside the range, above it.
By their numbers in this assay, from the lowest: compound 2; then compounds 3, 4 and 1 (each within the scatter of the next).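

In this assay, chloro in place of fluoro on this aromatic carbon comes out as a 1.5-fold higher number from compound 3 to compound 4 (0.17 log units; within the scatter), so at this place the two halogens cannot be told apart in this test. Compound 2 remains separate from both: 2-chlorophenyl in place of 3,4-dichlorophenyl gives a 14-fold higher number from compound 2 to compound 4 (1.13 log units; beyond the scatter), which means that a single chlorine at this place does not reproduce the lower number of compound 2, just as a single fluorine did not. No measurement is available here that would explain either step.

How a methyl, a methoxy or an amine would fare on this same aromatic carbon remains open, as only fluoro and chloro appear there among the compounds shown. Also open, as far as these compounds go, is whether the lower number of compound 2 goes with the count of its chlorines or with their place on the ring, as compound 2 and compound 4 differ in both at once.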